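Swapping the chain on the shared core: compound 3 to compound 4

A few compounds are considered here, and "the series" means these few. Any claim that something is new, unique, unknown or untested is made for them only; others in the source may bear on it.

Measured so far:
Compound 1 `Nc1nc(O)c2c(n1)n(C1OC(CO)[C@@H](O)[C@H]1O)c(=O)n2Cc1ccc(Cl)c(Cl)c1` — 55%
Compound 2 `Nc1nc(O)c2c(n1)n(C1OC(CO)[C@@H](O)[C@H]1O)c(=O)n2Cc1ccc([N+](=O)[O-])cc1` — 147%
Compound 3 `CN(C)CCCn1c(=O)n(C2OC(CO)[C@@H](O)[C@H]2O)c2nc(N)nc(O)c21` — 83%

In a functional assay on the whole organism (B cells) with Mus musculus as the target (a lower number here means a smaller maximal response, a higher number a larger maximal response), compound 3 stands second highest of the three numbers. Its nearest neighbour is compound 1, which gives 55%; the furthest is compound 2, which gives 147%. The step of a number 28 percentage points higher from compound 1 to compound 3 (beyond the scatter) is modest, whereas the step of a number 64 percentage points lower from compound 2 to compound 3 (beyond the scatter) is large, so the two aromatic groups on the saturated chain carbon bound to an aromatic nitrogen sit on either side of compound 3 with a wide spread between them.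

Compound 4 `Nc1nc(O)c2c(n1)n(C1OC(CO)[C@@H](O)[C@H]1O)c(=O)n2C/C=C/c1ccccc1` has not yet been measured. It differs from compound 3 in one place: 2-phenylethenyl in place of 2-(dimethylamino)ethyl on a saturated chain carbon bound to an aromatic nitrogen. Both steps above bear on this change, since each replaces an aromatic group at the same place with the 2-(dimethylamino)ethyl chain, and they point in opposite directions. A phenyl-bearing group returning to that position could thus land anywhere between the values of compound 1 and compound 2, so compound 4 is expected to show a step of a number 12 percentage points higher from compound 3 to compound 4 (beyond the scatter) in this assay, with wide uncertainty. Compound 4 is therefore estimated at 95%, with a range from 50% to 150%.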

Compound 4, largest response reached (reported as maximal response), in percent of the reference or control that the assay uses: 73%
Estimate against measurement, compound 4: 22 percentage points above; the range from low to high includes it.
By their numbers in this assay, from the lowest: compound 1; then compounds 4 and 3 (each within the scatter of the next); then compound 2.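

In this assay, the step of a number 10 percentage points lower from compound 3 to compound 4 (within the scatter) shows that the 3-phenylprop-2-en-1-yl chain and the 3-(dimethylamino)propyl chain cannot be told apart at this place, so a chain with an aromatic ring and a chain with an amine can give a similar maximal response. The new chain also separates from both ring-bearing groups, with a large step of a number 74 percentage points lower from compound 2 to compound 4 (beyond the scatter) and a modest step of a number 18 percentage points higher from compound 1 to compound 4 (beyond the scatter), so among the four compounds the high response of compound 2 is not shared by the other two groups that carry a phenyl ring. No measurement at hand explains these differences.

From the compounds shown here alone, what a plain phenyl, a 4-cyanophenyl or a 4-methoxyphenyl group would give on the same saturated chain carbon remains open, and with it whether the nitro group alone accounts for the response of compound 2. Also open, going by these compounds, are whether a saturated 3-phenylpropyl chain would read like compound 4, and whether a chain carrying a carboxylic acid in place of the dimethylamino group would read like compound 3.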